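Growth inhibition series: from compound 3 to compound 4

The source may report more compounds than this note shows. Statements on the series, on what has been measured and on what is new or still open speak of the compounds shown alone.

In a functional assay on MDA-MB-231 cells (Homo sapiens) for inhibition, read by sulforhodamine B assay, with a stated time of 72 h (a lower number here means a stronger inhibitor of growth, a higher number a weaker inhibitor of growth), compound 1 `CCOC(=O)/C=C/c1ccncc1-c1ccc2[nH]ccc2c1` gives only a limit, > 10000 nM. Compound 2 `CNC(=O)/C=C/c1ccncc1-c1ccc2[nH]ccc2c1` likewise gives only a limit, > 10000 nM. The step that the two limits leave unreadable from compound 1 to compound 2 is therefore unreadable, as the limit of > 10000 nM in this assay, at which 2 of the 3 values shown sit, shows. Within the data shown here, compound 3 `CNC(=O)/C=C/c1ccncc1-c1ccc2ccccc2c1` is the one compound with a number, 8680 nM in this assay. Compound 4 `NNC(=O)CCc1ccncc1-c1ccc2ccccc2c1` is not yet measured; it differs from compound 3 as 2-(aminocarbamoyl)ethyl in place of 2-(methylcarbamoyl)ethenyl on an aromatic carbon. Among the measured compounds shown here, none of the measured steps touches this change, so no size or direction can be drawn from them. For the measured compounds named here, with no steps to lean on, the expected step of a 1.0-fold higher number from compound 3 to compound 4 (0.02 log units; within the scatter) is none beyond the scatter. Compound 4 is thus estimated at 9000 nM, with a wide range from 3000 nM to 30000 nM.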

Compound 4, concentration for 50% growth inhibition: > 10000 nM
Compound 4 was reported as a limit (the forecaster's own chance of this, stated with the estimate: 45%); middle value at least 1.1-fold (0.04 log units) from the limit.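

Putting 2-(aminocarbamoyl)ethyl in place of 2-(methylcarbamoyl)ethenyl on this aromatic carbon, opposite the ring nitrogen, gives an at least 1.1-fold higher number from compound 3 to compound 4 (0.06 log units; that floor lies within the scatter) in this assay. Nothing here shows the new group giving stronger growth inhibition than the old one, but whether it is truly weaker cannot be read. The value of compound 4 is only a limit, and the size of the step stays hidden because of that ceiling: the limit of > 10000 nM in this assay, at which 3 of the 4 values shown sit.

Going by these compounds, two things change at once here, the chain and its end, so the effect of each remains open. A 2-(methylcarbamoyl)ethyl group or a carboxylic acid at this position would help separate them.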